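Series notes: hydrogen in place of methoxy on the benzyl ring

The source may hold more compounds than are shown below. What is called first, only, known or untested is meant among the compounds shown, and "the series" means these compounds.

Measured compounds:
- Compound 1 `COCOc1ccc(Cc2ccc3cc(NC(=O)c4ccc(OC(C)=O)c(CC=C(C)C)c4)c(=O)oc3c2C)cc1OC`: in a functional assay on SK-BR-3 cells (Homo sapiens) for antiproliferative activity (on this read-out lower numbers stand for stronger inhibition and higher numbers for weaker inhibition), compound 1 gives 14200 nM.
- Compound 2 `COc1cc(Cc2ccc3cc(NC(=O)c4ccc(O)c(CC=C(C)C)c4)c(=O)oc3c2C)ccc1O`: in this assay compound 2 gives 10700 nM.
- Compound 3 `COCOc1ccc(Cc2ccc3cc(NC(=O)c4ccc(OC(C)=O)c(CC=C(C)C)c4)c(=O)oc3c2C)cc1`: in this assay compound 3 gives 13500 nM.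

All three numbers sit within the scatter of one another. For the measured compounds named here, the only single-point step measured is hydrogen in place of methoxy on an aromatic carbon, which gives a 1.1-fold lower number from compound 1 to compound 3 (0.02 log units; within the scatter). How compound 2 differs from compound 1 is not broken down here.

Compound 4 `CC(C)=CCc1cc(C(=O)Nc2cc3ccc(Cc4ccc(O)cc4)c(C)c3oc2=O)ccc1O` differs from compound 2 by hydrogen in place of methoxy on an aromatic carbon. This is the same kind of change as from compound 1 to compound 3, but the surroundings differ: in compound 2 the place is ortho to a hydroxy group, whereas in compound 1 it is ortho to a methoxymethoxy group.

For compound 4 the step is expected to be a 1.1-fold lower number from compound 2 to compound 4 (0.03 log units; within the scatter), because a 1.1-fold lower number from compound 1 to compound 3 (0.02 log units; within the scatter) lay within the scatter. Compound 4 is therefore estimated at 10000 nM, between 5000 nM and 21000 nM.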

Compound 4, half-maximal inhibitory concentration: 21500 nM
For compound 4 the middle estimate is 2.2-fold (0.33 log units) below the measured one, outside the stated range (above it).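

Hydrogen in place of methoxy on the benzyl ring gives a 2.0-fold higher number from compound 2 to compound 4 (0.30 log units; within the scatter) in this assay. Set beside the earlier step, the two cores cannot be told apart: the same change on two cores in this assay, a 1.1-fold lower number (0.02 log units; within the scatter) from compound 1 to compound 3 and a 2.0-fold higher number (0.30 log units; within the scatter) from compound 2 to compound 4, 2.1-fold (0.33 log units) apart, within the scatter of two such steps. This shows that, within the resolution of the measurements, the change carries from the core of compound 1 to the core of compound 2, but it does not show that the step is identical on both cores, and two pairs of compounds support no general rule for the series.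

The compounds shown leave open what an ethoxy group, a fluorine or an amine would give in the same place. They also leave open whether this change stays within the scatter on other cores.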